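Aryl swap at the hydrazone carbon: compound 4

The compounds below may be only part of what the source reports. "The series", "measured", "known", "first", "only" and "open" are said of these compounds alone.

Compound 1 `CN(C)CCn1cnnc1-c1cc(Oc2ccc(NC(=O)N/N=C/c3cccc(Br)c3)cc2F)ccn1`: 380 nM
Compound 2 `CN(C)CCn1cnnc1-c1cc(Oc2ccc(NC(=O)N/N=C/c3ccc(F)cc3Cl)cc2F)ccn1`: 510 nM
Compound 3 `CN(C)CCn1cnnc1-c1cc(Oc2ccc(NC(=O)N/N=C/c3c(O)ccc4ccccc34)cc2F)ccn1`: 670 nM

In a functional assay on HT-29 cells (Homo sapiens) for cytotoxicity, read by MTT assay, with a stated time of 72 h (a lower number here means a stronger inhibitor, a higher number a weaker inhibitor), compound 2 holds the second highest of the three numbers; its neighbours are close, with a 1.3-fold higher number from compound 2 to compound 3 (0.12 log units; within the scatter) and a 1.3-fold higher number from compound 1 to compound 2 (0.13 log units; within the scatter), both within the scatter. Compound 4 `COc1ccc(/C=N/NC(=O)Nc2ccc(Oc3ccnc(-c4nncn4CCN(C)C)c3)c(F)c2)c(OC)c1` differs from compound 2 only at the aryl group on the hydrazone carbon: 2,4-dimethoxyphenyl in place of 2-chloro-4-fluorophenyl on a carbon with a double bond to nitrogen. The two measured steps at this very position, a 1.3-fold higher number from compound 1 to compound 2 (0.13 log units; within the scatter) and a 1.3-fold higher number from compound 2 to compound 3 (0.12 log units; within the scatter), were both within the scatter, so changing this aryl group has so far left the half-maximal inhibitory concentration essentially unchanged. The step of a 1.2-fold higher number from compound 2 to compound 4 (0.07 log units; within the scatter) is therefore expected to stay within the scatter. Compound 4 is estimated at 600 nM, within 250 nM to 1500 nM.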

Compound 4, half-maximal inhibitory concentration: 1780 nM
Beside the measured number, compound 4's estimate is 3.0-fold (0.47 log units) below it; measured number outside the range, above it.
By their numbers in this assay, from the lowest: compounds 1, 2 and 3 (each within the scatter of the next); then compound 4.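

In this assay the aryl group on the hydrazone carbon does matter: 2,4-dimethoxyphenyl gives a 3.5-fold higher number from compound 2 to compound 4 (0.54 log units; beyond the scatter) and a 2.7-fold higher number from compound 3 to compound 4 (0.42 log units; beyond the scatter) and a 4.7-fold higher number from compound 1 to compound 4 (0.67 log units; beyond the scatter), each modest but beyond the scatter. Swaps among 3-bromophenyl, 2-chloro-4-fluorophenyl and 2-hydroxynaphthalen-1-yl had produced no step of that kind. Nothing measured here accounts for this change. As far as these compounds go, it remains open whether 2-methoxyphenyl or 4-methoxyphenyl alone would give the same rise. Also open, from the compounds shown here alone, is how an aryl group carrying an amine or a carboxylic acid would behave at this position.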